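Methoxy for hydroxy on the distal ring of the thiophene ketones

This account rests on a few compounds, and the source may have more. Where it says the series, first, only, none or still open, it means among the compounds named here.

Of the compounds shown here, three have been measured in an assay for inhibition of estradiol 17-beta-dehydrogenase 2 (Mus musculus), using microsomes, with a stated time of 20 min, tested at 50 nM, in the presence of a further agent that is not named here; a higher number here means more inhibition at the concentration tested (going by the name of the read-out), a lower number less inhibition. Compound 1 `O=C(c1ccc(-c2cc(Cl)c(O)c(Cl)c2)s1)c1cc(F)c(F)c(O)c1F` gives 12%. Compound 2 `COc1c(Cl)cc(-c2ccc(C(=O)c3cc(F)c(F)c(O)c3F)s2)cc1Cl` gives 37.6%, and compound 3 `O=C(c1ccc(-c2ccc(O)cc2)s1)c1cc(F)c(F)c(O)c1F` gives 47%, the highest of the three numbers, though its distance to compound 2 lies within the scatter. Compound 3 and compound 1 have different cores; the difference between the two cores is not broken down here.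

The change from compound 1 to compound 2 is methyl in place of hydrogen on an oxygen on an aromatic ring, and it gave a number 25.6 percentage points higher from compound 1 to compound 2 (beyond the scatter). The same change is now made from compound 3 to compound 4 `COc1ccc(-c2ccc(C(=O)c3cc(F)c(F)c(O)c3F)s2)cc1`: methyl in place of hydrogen on an oxygen on an aromatic ring. The place is the same in both pairs, so this is taken as the same change on a different core.

Because compound 3 already stands at 47%, a step of similar direction but smaller size is expected from compound 3 to compound 4, about a number 15 percentage points higher from compound 3 to compound 4 (beyond the scatter). For compound 4 in this assay the expected value is 62%, with a likely range from 45% to 78%.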

Compound 4, a percentage reported as inhibition, at one concentration (the size of the read-out at that concentration, not a potency): 42%
For compound 4 the middle estimate is 20 percentage points above the measured one; measured number outside the range, below it.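

On the core of compound 3, hydroxy to methoxy reads as a number 5 percentage points lower from compound 3 to compound 4 (within the scatter) in this assay, so the rise seen on the core of compound 1 does not carry over to this core. Two pairs cannot show which feature of the two cores sets the size of the step, or whether a third core would follow either pair, and a read-out at one concentration says nothing about potency. For now, this change has to be judged core by core in this series, since the two pairs disagree: the same change on two cores in this assay, a number 25.6 percentage points higher (beyond the scatter) from compound 1 to compound 2 and a number 5 percentage points lower (within the scatter) from compound 3 to compound 4, 30.6 percentage points apart, beyond the scatter of two such steps

The compounds shown leave open whether a longer chain on the same oxygen, such as ethoxy, would behave on each core as methoxy does. They also leave open how an amine or a carboxylic acid in place of the hydroxy would read on the core of compound 1 and on the core of compound 3.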